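This account rests on a few compounds, and the source may have more. Where it says the series, first, only, none or still open, it means among the compounds named here.

Working notes on a set of four analogues sharing one core, read in a functional assay on Hep 3B2 cells (Homo sapiens) for inhibition, read by sulforhodamine B assay, with a stated time of 72 h, tested at 10 uM; on this read-out higher numbers stand for more inhibition at the one concentration tested (going by the name of the read-out) and lower numbers for less inhibition. Compound 1 `C[C@H](Nc1ncnc2[nH]cnc12)c1nn(-c2cccnc2)c2ccc(F)cc12` gives 13% in this assay. Compound 2 `C[C@H](Nc1nc(N)nc2[nH]cnc12)c1nn(-c2cccnc2)c2cc(F)ccc12` gives 14% in this assay. Compound 3 `C[C@H](Nc1ncnc2[nH]cnc12)c1nn(-c2ccc(C#N)cc2)c2cc(F)ccc12` gives 46% in this assay, the highest of the three numbers; its gap to compound 2 and its gap to compound 1 both lie beyond the usual scatter, so compound 3 has the highest inhibition in this assay of the measured compounds. Going by the values given here, compounds 1 and 2 each differ from compound 3 in more than one place, so no single-change step between measured compounds can be drawn from these three.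

Compound 4 `C[C@H](Nc1ncnc2[nH]cnc12)c1nn(-c2ccncc2)c2cc(F)ccc12` has not been measured. It differs from compound 3 in one place only: pyridin-4-yl in place of 4-cyanophenyl on an aromatic nitrogen. Among the compounds with values here, the only measured compounds that carry no nitrile on that aromatic nitrogen, compound 1 at 13% and compound 2 at 14%, both sit far below compound 3, although neither is a single-change neighbour of compound 4. On that basis the step from compound 3 to compound 4 in this assay is expected to be a decrease beyond the scatter, a number 24 percentage points lower from compound 3 to compound 4 (beyond the scatter). Compound 4 is therefore estimated at 22% in this assay, with a range from 5% to 45%.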

Compound 4, a percentage reported as inhibition, at one concentration (the size of the read-out at that concentration, not a potency): 5%
Compound 4: the middle estimate sits 17 percentage points above what was measured; the measured number falls inside the stated range.
By their numbers in this assay, from the lowest: compounds 4, 1 and 2 (each within the scatter of the next); then compound 3.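

In this assay, going by these compounds alone, the change to pyridin-4-yl in place of 4-cyanophenyl on an aromatic nitrogen gives a number 41 percentage points lower from compound 3 to compound 4 (beyond the scatter); this is the first comparison with the rest of the molecule held constant, which compound 1 and compound 2 could not provide, and it shows that the group at this position alone can shift the read-out by a large amount. The two groups have the same counts of hydrogen-bond donors and acceptors and the same net charge, so these counts do not separate them; the differences lie in the ring hetero atom, the triple bond outside the ring and the smaller heavy-atom count of pyridin-4-yl. No measurement shown here accounts for the size of this step.

Within the data shown here, the single change replaces the whole group, so the contributions of the nitrile and of the ring nitrogen remain unseparated; a plain phenyl on the same aromatic nitrogen would divide the step between them. Going by these compounds, it also remains open whether other groups on that phenyl ring, such as an amine or a carboxylic acid, would stand close to 4-cyanophenyl or to pyridin-4-yl on this read-out.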